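Amide-linked heteroaryl swap on a shared thiazolidinedione core

A few compounds are considered here, and "the series" means these few. Any claim that something is new, unique, unknown or untested is made for them only; others in the source may bear on it.

compound 1 `O=C(COc1ccc(/C=C2\SC(=O)NC2=O)cc1)Nc1nc2ccccc2s1` — a functional assay on KB cells (Homo sapiens) for cytotoxicity, read by sulforhodamine B assay, with a stated time of 48 h; a higher number here means a weaker inhibitor of growth, a lower number a stronger inhibitor of growth < 100000 nM
compound 2 `O=C(COc1ccc(/C=C2\SC(=O)NC2=O)cc1)Nc1ncc([N+](=O)[O-])s1` — this assay < 100000 nM

Both entries are limits of the assay, not numbers. The value of compound 1 is a limit. The value of compound 2 is a limit as well, so compound 2 sits at the limit of < 100000 nM in this assay, at which 2 of the 2 values shown sit. The step that the two limits leave unreadable from compound 1 to compound 2 thus has no readable size. Compound 3 `Cc1cc(NC(=O)COc2ccc(/C=C3\SC(=O)NC3=O)cc2)no1` differs from compound 2 by 5-methyl-1,2-oxazol-3-yl in place of 5-nitro-1,3-thiazol-2-yl on an amide-type nitrogen. Within the data shown here, no measured step bears readably on this change, so the expected step that the limit leaves unreadable from compound 2 to compound 3 is set at none beyond the scatter. Compound 3 is estimated at 60000 nM, with a range from 15000 nM to 100000 nM, most likely again reported only as a limit.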

Compound 3, concentration for total growth inhibition: < 100000 nM
Compound 3 ended at the assay's limit; the forecaster's own chance of this, stated with the estimate: 65%; the middle value is on the limit's open side.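

Among these compounds, compound 1, compound 2 and compound 3 all stand at a limit, not a number, so no step among them can be read: the limit of < 100000 nM in this assay, at which 3 of the 3 values shown sit.

The compounds shown leave open how the three heteroaryl groups on the amide nitrogen compare in this assay.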